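Cyclopentyl replacing hydroxyethylamino in the amide series

This account rests on a few compounds, and the source may have more. Where it says the series, first, only, none or still open, it means among the compounds named here.

Of the compounds shown here, two have been measured in an assay for antagonist activity at P2X purinoceptor 7 (Homo sapiens), read by ELISA, with a stated time of 30 min; a lower number here means a stronger inhibitor, a higher number a weaker inhibitor. Compound 1 `COCCOc1ccc2c(C(=O)NCC3CCC(F)(F)CC3)c(Cl)ccc2n1` gives 140 nM. Compound 2 `O=C(NCC1CCC(F)(F)CC1)c1c(Cl)ccc2nc(NCCO)ccc12` gives 76 nM; the step of a 1.8-fold lower number from compound 1 to compound 2 (0.27 log units; within the scatter) is within the scatter, so the two numbers are not distinguished on this evidence, and compound 2 simply stands at one of two values that agree with each other.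

Compound 3 `O=C(NCC1CCC(F)(F)CC1)c1c(Cl)ccc2nc(C3CCCC3)ccc12` has not yet been measured in this assay. Its change from compound 2 is cyclopentyl in place of (2-hydroxyethyl)amino on an aromatic carbon. For the measured compounds named here, the only measured step, a 1.8-fold lower number from compound 1 to compound 2 (0.27 log units; within the scatter), exchanges one oxygen- and nitrogen-bearing chain for another at the same place and therefore says little about a carbocyclic ring there; it shows only that this position tolerated a change of substituent without a shift beyond the scatter. Going by the values given here, with no step that bears directly on the cyclopentyl group, no step beyond the scatter is expected in this assay, but the uncertainty is wide. Compound 3 is estimated at 110 nM, within 30 nM to 450 nM, which means an expected step of a 1.4-fold higher number from compound 2 to compound 3 (0.16 log units; within the scatter).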

Compound 3, half-maximal inhibitory concentration: 160 nM
The estimate for compound 3 lay 1.5-fold (0.16 log units) below the measured number; the measured number falls inside the stated range.
By their numbers in this assay, from the lowest: compounds 2, 1 and 3 (each within the scatter of the next, the first and the last beyond it).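

In this assay, cyclopentyl puts a carbon-only ring, with 0 hydrogen-bond donors and 0 hydrogen-bond acceptors, on the aromatic carbon next to the ring nitrogen, and the series now shows a 2.1-fold higher number from compound 2 to compound 3 (0.32 log units; beyond the scatter), its first step beyond the scatter, though a modest one. Set against the 2-methoxyethoxy chain, the same ring gives a 1.1-fold higher number from compound 1 to compound 3 (0.06 log units; within the scatter), so this position accepts a ring of carbon only with no distinction from that chain, and only the comparison with the (2-hydroxyethyl)amino group separates the values at all. Nothing available here accounts for the step from the (2-hydroxyethyl)amino group to cyclopentyl.

The exchange removes the hydroxyl and the amine nitrogen and adds the ring all at once, so the compounds shown do not assign the step to any one of these changes. A plain amino group, a 2-methoxyethylamino chain or a cyclopentylamino group at this carbon would pull these changes apart, and a phenyl ring would test whether a saturated ring is needed here.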